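The source may report more compounds than this note shows. Statements on the series, on what has been measured and on what is new or still open speak of the compounds shown alone.

Measured so far:
compound 1, `CC(C)CN(NC(=O)OCc1ccccc1)C(=O)CN(Cc1ccccc1)NC(=O)CBr` — 1800 nM
compound 2, `CC(C)CN(CC(=O)NN(Cc1ccccc1)c1cnccn1)NC(=O)CBr` — 14800 nM
compound 3, `CC(C)CN(NC(=O)OCc1ccccc1)C(=O)CN(Cc1ccccc1)NC(=O)Cc1cccc(Br)c1` — 15800 nM

All three were run in a functional assay on B16 cells (Mus musculus) for inhibition; a higher number here means a weaker inhibitor, a lower number a stronger inhibitor. Compound 1 and compound 3 share a core and differ in one place: 3-bromophenyl in place of bromo on a saturated chain carbon bound to a carbonyl carbon. That change gave an 8.8-fold higher number from compound 1 to compound 3 (0.94 log units; beyond the scatter). Compound 2 sits on a different core; how the core of compound 2 differs from the core of compound 1 is not broken down here. In this assay compound 2 gives 14800 nM, which lies within the scatter of compound 3, while compound 1 gives a clearly lower number than compound 2.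

Compound 4, `CC(C)CN(CC(=O)NN(Cc1ccccc1)c1cnccn1)NC(=O)Cc1cccc(Br)c1`, is not yet measured. It is compound 2 carrying the same change: 3-bromophenyl in place of bromo on a saturated chain carbon bound to a carbonyl carbon. The place is the same as in the pair from compound 1 to compound 3, so the change is the same, made on the core of compound 2 instead.

The expectation for compound 4 rests on one measured instance of the change. The step from compound 2 to compound 4 is expected to be a 4.1-fold higher number from compound 2 to compound 4 (0.61 log units; beyond the scatter), set somewhat smaller than the earlier step because an 8.8-fold higher number from compound 1 to compound 3 (0.94 log units; beyond the scatter) was measured on a different core and compound 2 already starts from a high number. On that basis compound 4 is estimated at 60000 nM in this assay, with a plausible range from 15000 nM to 200000 nM; a result reported only as a limit is possible for compound 4.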

Compound 4, half-maximal inhibitory concentration: 33300 nM
For compound 4 the middle estimate is 1.8-fold (0.26 log units) above the measured one, and the stated range covers the measured number.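

In this assay, the change from bromo to 3-bromophenyl on a saturated chain carbon bound to a carbonyl carbon again raises the number on the second core (a 2.3-fold higher number from compound 2 to compound 4 (0.35 log units; beyond the scatter)), so the direction of the step is the same on both cores shown. The size of the step does not carry over from one core to the other, and any forecast for a further core in this series can borrow the direction from these two pairs more safely than the magnitude: the two steps stand apart as follows: the same change on two cores in this assay, an 8.8-fold higher number (0.94 log units; beyond the scatter) from compound 1 to compound 3 and a 2.3-fold higher number (0.35 log units; beyond the scatter) from compound 2 to compound 4, 3.9-fold (0.59 log units) apart, beyond the scatter of two such steps. These two pairs do not show why the step is larger on one core than on the other, nor whether the same direction would hold on a third core, as the data consist of a single pair on each core in one cell assay.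

The compounds shown leave open whether the gap between the two steps is tied to this particular exchange or would also appear with other groups at the same place, such as chloro, an unsubstituted phenyl, an amine or a carboxylic acid. They also leave open how much of the rise on each core comes from the phenyl ring and how much from its bromine.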